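Phenyl in place of cyclohexyl on a shared core

The compounds below may be only part of what the source reports. "The series", "measured", "known", "first", "only" and "open" are said of these compounds alone.

Compound 1 `C[C@@H](Nc1nc(O)c2cc(Cl)ccc2n1)C1CCCCC1` and compound 2 `C[C@H](Nc1nc(O)c2cc(Cl)ccc2n1)C1CCCCC1` are built on the same core and differ only in how one centre is drawn (the fact that compounds 1 and 2 differ only in the configuration as drawn). In a functional assay on the whole organism (uterus) with Rattus norvegicus as the target, tested at 10 uM (on this read-out lower numbers stand for a stronger effect and higher numbers for a weaker effect at the one concentration tested), compound 1 gives 108%, and in this assay compound 2 gives 102%. Compound 1 has the higher of the two numbers, yet the step of a number 6 percentage points lower from compound 1 to compound 2 (within the scatter) is within the scatter, so the two cannot be told apart. Compound 3 `C[C@@H](Nc1nc(O)c2cc(Cl)ccc2n1)c1ccccc1` has not been measured; it differs from compound 1 in one place: phenyl in place of cyclohexyl on a saturated chain carbon bound to a nitrogen on an aromatic ring and a saturated chain carbon. For the measured compounds named here, no measured step touches this group: the only step known, the one a number 6 percentage points lower from compound 1 to compound 2 (within the scatter), concerns configuration alone and stayed within the scatter. The numbers therefore give no basis to expect a step beyond the scatter in this assay in either direction. Compound 3 is expected to give about 105%, between 90% and 120%. The expected step is a number 3 percentage points lower from compound 1 to compound 3 (within the scatter).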

Compound 3, a percentage reported as activity, at one concentration (the size of the read-out at that concentration, not a potency): 120%
Estimate against measurement, compound 3: 15 percentage points below, and the stated range covers the measured number.
By their numbers in this assay, from the lowest: compounds 2 and 1 (each within the scatter of the next); then compound 3.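

In this assay, for the compounds shown here, the swap of cyclohexyl for phenyl gives a number 12 percentage points higher from compound 1 to compound 3 (beyond the scatter) as the first step in this set that lies beyond the scatter, and it points towards a weaker effect. The configuration at this saturated chain carbon moved the number only within the scatter, as a number 6 percentage points lower from compound 1 to compound 2 (within the scatter) shows, whereas replacing a non-aromatic ring of carbon with an aromatic one does register, if modestly. Nothing available explains why these two six-membered rings read differently.

The compounds shown leave open whether the opposite configuration matters once phenyl is in place, as it did not detectably with cyclohexyl. They also leave open how a longer alkyl chain, an amine or a carboxylic acid on this carbon would read out, and whether any group here could give a clearly stronger effect.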